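The source may hold more compounds than are shown below. What is called first, only, known or untested is meant among the compounds shown, and "the series" means these compounds.

Measured in an in vivo ADME assay on the whole organism (strain Sprague-Dawley) for metabolic stability, with Rattus norvegicus as the target, at a dose of 2.5 mg/kg by the intravenous route; a lower number here means that the compound disappears faster, a higher number that the compound lasts longer:
Compound 1 `Nc1ccccc1NC(=O)c1ccc(CN2Cc3ccccc3C2=O)cc1`: 0.6 h
Compound 2 `Nc1ccccc1NC(=O)c1ccc(Cn2cnc3ccsc3c2=O)cc1`: 1.4 h
Compound 3 `Nc1ccccc1NC(=O)c1ccc(Cn2c(=O)[nH]c3ccsc3c2=O)cc1`: 1.3 h

Compound 3 and compound 2 lie within the scatter of each other, while compound 3 lasts longer than compound 1 by a gap beyond the scatter. Compound 4 `CCn1c(=O)n(Cc2ccc(C(=O)Nc3ccccc3N)cc2)c(=O)c2sccc21` differs from compound 3 by ethyl in place of hydrogen on an aromatic nitrogen, with ethyl in place of hydrogen on an aromatic nitrogen. Among the compounds with values here, no measured pair shows this change, so the expectation starts from compound 3 at 1.3 h. No shift beyond the scatter is expected in this assay, and the estimated 1.1-fold lower number from compound 3 to compound 4 (0.03 log units; within the scatter) is small and downward. Compound 4 is expected at 1.2 h, with an estimated range from 0.6 h to 2.4 h.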

Compound 4, half-life: 1.2 h
The estimate for compound 4 equals the measured number at the digits printed; low and high end bracket the measured number.
By their numbers in this assay, from the lowest: compounds 1, 4, 3 and 2 (each within the scatter of the next, the first and the last beyond it).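

In this assay, ethyl in place of hydrogen on an aromatic nitrogen gives a 1.1-fold lower number from compound 3 to compound 4 (0.03 log units; within the scatter), so the half-lives of the two compounds cannot be told apart. Within the data shown here, this is the first step at this nitrogen, and it shows that the position takes an ethyl group, with its two carbons and the loss of that hydrogen, without a shift beyond the scatter. Nothing available bears on the reason for this result. As far as these compounds go, whether a longer chain, an amine or a carboxylic acid on this nitrogen would also leave the half-life within the scatter stays open.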